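The source may hold more compounds than are shown below. What is called first, only, known or untested is meant among the compounds shown, and "the series" means these compounds.

Measured compounds:
- compound 1, `O=C1C(Nc2ccc(F)cc2F)=CC(=O)c2ncccc21`, gives 94%
- compound 2, `O=C1C(Nc2ccc(F)c(F)c2F)=CC(=O)c2ncccc21`, gives 72%
- compound 3, `O=C1C=C(Nc2ccc(F)cc2)C(=O)c2cnccc21`, gives 72%

All three numbers come from a functional assay on the whole organism (aorta) with Rattus norvegicus as the target; on this read-out lower numbers stand for smaller maximal responses and higher numbers for larger maximal responses. Compound 1 and compound 2 share one core; compound 2 carries one more fluoro group, the change being (fluoro in place of hydrogen on an aromatic carbon). That change moved the maximal response by a number 22 percentage points lower from compound 1 to compound 2 (beyond the scatter). Compound 3 stands on a different core; the difference between the two cores is not broken down here. In this assay compound 3 gives a value level with that of compound 2, and both sit well under compound 1.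

Compound 4, `O=C1C=C(Nc2ccc(F)cc2F)C(=O)c2cnccc21`, is not yet measured. Against compound 3 it differs by fluoro in place of hydrogen on an aromatic carbon, again fluoro in place of hydrogen on an aromatic carbon. This is the same kind of change as that from compound 1 to compound 2, not the same: there the entering fluoro stood ortho to two fluoro groups and meta to a large group, here it stands ortho to a large group and meta to a fluoro group.

Among the compounds with values here, the only precedent for adding a fluoro group to the aryl ring is the drop seen from compound 1 to compound 2, so a step of similar direction is expected from compound 3 to compound 4, estimated at a number 14 percentage points lower from compound 3 to compound 4 (beyond the scatter), though its size rests on a single measured pair on another core and on a different place around the ring. Compound 4 is therefore expected to reach about 58% in this assay, with a likely range from 40% to 78%.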

Compound 4, largest response reached (Emax), in percent of the reference or control that the assay uses: 96%
Estimate against measurement, compound 4: 38 percentage points below; the measured number lies above the stated range.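

In this assay, fluoro in place of hydrogen on an aromatic carbon gives a number 24 percentage points higher from compound 3 to compound 4 (beyond the scatter), so the earlier step on the other core does not predict this one, and the two steps run in opposite directions: the same change on two cores in this assay, a number 22 percentage points lower (beyond the scatter) from compound 1 to compound 2 and a number 24 percentage points higher (beyond the scatter) from compound 3 to compound 4, 46 percentage points apart, beyond the scatter of two such steps. For this series, a step measured for this change on one core therefore cannot be carried to the other core as a guide to either direction or size. This does not show that the core alone sets the outcome, since the entering fluoro also stands at a different place on the aryl ring in each pair, and one pair per core cannot separate the two differences or establish a rule for either core.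

The compounds shown leave open whether a fluoro group entering at the same place on the ring would move the maximal response the same way on both cores. They also leave open whether a chloro group, a methoxy group or an amine on the aryl ring would follow either of the two fluoro steps, or whether such changes would depend on the core as well.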